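Coumarin-Pyrazoline Amides: From Propylamine to Cyclopropylamine

The source may hold more compounds than are shown below. What is called first, only, known or untested is meant among the compounds shown, and "the series" means these compounds.

Compound 1 `Cc1ccc(C(=O)N2N=C(c3cc4ccccc4oc3=O)CC2c2ccccc2)cc1` gives 13200 nM in a functional assay on PC-3 cells (Homo sapiens) for cytotoxicity, read by MTT assay, with a stated time of 48 h; a higher number here means a weaker inhibitor, a lower number a stronger inhibitor.
Compound 2 `O=C(c1ccccc1Cl)N1N=C(c2cc3ccccc3oc2=O)CC1c1ccccc1` gives 6370 nM in this assay.
Compound 3 `CCCNCC(=O)N1N=C(c2cc3ccccc3oc2=O)CC1c1ccccc1` gives 7270 nM in this assay.

The three measured compounds share a common core and differ only in the group on the carbonyl carbon. The step of a 2.1-fold lower number from compound 1 to compound 2 (0.32 log units; beyond the scatter) is the only one that exceeds the scatter; the steps of a 1.8-fold lower number from compound 1 to compound 3 (0.26 log units; within the scatter) and a 1.1-fold higher number from compound 2 to compound 3 (0.06 log units; within the scatter) are both within it, so compound 3 cannot be placed above or below either neighbour on these numbers; it sits close to compound 2 and compound 1 alike.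

Compound 4 `O=C(CNC1CC1)N1N=C(c2cc3ccccc3oc2=O)CC1c1ccccc1` is the next member. Its change from compound 3 is cyclopropyl in place of propyl on an amine nitrogen, a swap of the same number of heavy atoms on the amine nitrogen of the (propylamino)methyl arm. Among the compounds with values here, none of the measured steps touches this amine substituent: all three concern replacing the whole group on the carbonyl carbon. Within the data shown here, there is therefore no measured precedent for this change, and the nearest comparison, compound 2 to compound 3, was within the scatter. Compound 4 is accordingly expected to stay near compound 3, with a step of a 1.0-fold lower number from compound 3 to compound 4 (0.02 log units; within the scatter) not beyond the scatter. The estimate for compound 4 in this assay is 7000 nM, with a range from 3500 nM to 14000 nM.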

Compound 4, half-maximal inhibitory concentration: 28500 nM
For compound 4 the middle estimate is 4.1-fold (0.61 log units) below the measured one, and the stated range ends below it.
By their numbers in this assay, from the lowest: compounds 2, 3 and 1 (each within the scatter of the next, the first and the last beyond it); then compound 4.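

In this assay, within the data shown here, the amine substituent, which no earlier step had touched, proves to matter: with the heavy-atom count unchanged, cyclopropyl in place of propyl on the amine nitrogen gives a 3.9-fold higher number from compound 3 to compound 4 (0.59 log units; beyond the scatter) and this exceeds every step among compounds 1, 2 and 3. Compound 4 also lies beyond the scatter of both aryl amides, with a 4.5-fold higher number from compound 2 to compound 4 (0.65 log units; beyond the scatter) and a 2.2-fold higher number from compound 1 to compound 4 (0.33 log units; beyond the scatter) making it the weakest of the four compounds, so the two amine-bearing compounds do not behave as one group, even though the propylamino member could not be separated from either aryl amide. Nothing measured here explains why this small change has so large an effect on the number.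

The compounds shown leave open whether the step belongs to the three-membered ring itself or would follow any branched or cyclic group on this nitrogen, which an isopropyl, a cyclobutyl or a longer butyl chain there would help to separate. They also leave open how a piperidine or morpholine amine in place of the secondary amine would read in this assay on this same shared core.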